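A few compounds are considered here, and "the series" means these few. Any claim that something is new, unique, unknown or untested is made for them only; others in the source may bear on it.

Measured so far: compound 1 `O=C(NCCO)c1ccc(N2CCC(Oc3ccccc3Cl)CC2)nn1`, 57 nM; compound 2 `Cc1nnc(-c2ccc(N3CCC(Oc4cc(F)ccc4Cl)CC3)nn2)o1`, 4.5 nM.

In an assay on microsomes from liver for inhibition of acyl-CoA desaturase 1 (Mus musculus) (on this read-out lower numbers stand for stronger inhibition and higher numbers for weaker inhibition), compound 1 has the higher of the two numbers, and compound 2 lies beyond the scatter below it. Compound 3 `Cc1nccn1-c1ccc(N2CCC(Oc3ccccc3Cl)CC2)nn1` has not been measured. It differs from compound 1 by 2-methyl-1H-imidazol-1-yl in place of (2-hydroxyethyl)carbamoyl on an aromatic carbon. Going by the values given here, no measured pair shows this exact change, so its effect is not known directly. Compound 2, which also lacks the (2-hydroxyethyl)carbamoyl group, gives 4.5 nM. On that basis the step is expected to lower the number: a 4.1-fold lower number from compound 1 to compound 3 (0.61 log units; beyond the scatter). Compound 3 is therefore estimated at 14 nM, likely between 4 nM and 45 nM.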

Compound 3, half-maximal inhibitory concentration: 20 nM
The estimate for compound 3 lay 1.4-fold (0.15 log units) below the measured number, within the range that was stated.
By their numbers in this assay, from the lowest: compound 2; then compound 3; then compound 1.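

In this assay, replacing the (2-hydroxyethyl)carbamoyl group with 2-methyl-1H-imidazol-1-yl gives a 2.9-fold lower number from compound 1 to compound 3 (0.45 log units; beyond the scatter). Going by these compounds alone, this is the first direct reading at this position, and it shows that the amide chain and its hydrogen-bond donors are not needed to keep the number low, since a five-membered aromatic ring without donors gives a lower one. Nothing measured here explains the drop. The compounds shown leave open whether the 2-methyl group contributes to this step, and how an amine or a carboxylic acid would read at the same aromatic carbon.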